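Working notes: sulfanyl in place of amino on the shared core

This account rests on a few compounds, and the source may have more. Where it says the series, first, only, none or still open, it means among the compounds named here.

Measured in an assay for inhibition of CDP-diacylglycerol--inositol 3-phosphatidyltransferase (Mus musculus), tested at 5 mM; a lower number here means less inhibition, a higher number more inhibition at the concentration tested (going by the name of the read-out):
- compound 1, `CO[C@H]1C[C@@H](O)[C@H](O)[C@H](O)[C@H]1O`: compound 1 gives 28%
- compound 2, `N[C@H]1[C@@H](O)[C@H](O)[C@H](O)[C@@H](O)[C@H]1O`: compound 2 gives 19%

Compound 2 holds the lower of the two numbers, but its nearest neighbour, compound 1, sits within the usual scatter of it, so the two cannot be placed in order; both show modest inhibition at the single concentration tested. Among the compounds with values here, no pair of measured compounds differs in one place, so no isolated step is available for comparison.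

Compound 3, `O[C@@H]1[C@@H](O)[C@@H](O)[C@@H](S)[C@@H](O)[C@@H]1O`, is not yet measured in this assay. It differs from compound 2 by sulfanyl in place of amino on a saturated ring carbon. Both groups count one heavy atom, one hydrogen-bond donor and one hydrogen-bond acceptor, and both carry no net charge. With compound 1 and compound 2 sitting close together, no step beyond the scatter is expected from this exchange, and the estimated step is a number 2 percentage points higher from compound 2 to compound 3 (within the scatter).

For compound 3 the expected read-out is 21%, with a range from 6% to 36%.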

Compound 3, a percentage reported as inhibition, at one concentration (the size of the read-out at that concentration, not a potency): 40%
For compound 3 the middle estimate is 19 percentage points below the measured one; the whole stated range lies below it.
By their numbers in this assay, from the lowest: compounds 2 and 1 (each within the scatter of the next); then compound 3.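

In this assay, within the data shown here, the exchange of amino for sulfanyl on the saturated ring carbon gives a number 21 percentage points higher from compound 2 to compound 3 (beyond the scatter), the only step that isolates one place. This position therefore responds to the identity of the group it carries, although amino and sulfanyl match in heavy atoms, hydrogen-bond donors, hydrogen-bond acceptors and net charge, so those counts do not capture the difference. Nothing available bears on what lies behind the step.

The compounds shown leave open whether a hydroxy group, a methylsulfanyl group or a longer sulfur-linked chain at this carbon would match or exceed sulfanyl. As far as these compounds go, with a single amino-to-sulfanyl pair at one tested concentration, it also remains open whether the step would carry over to other positions on the shared core or reflect a difference in potency.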